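A few compounds are considered here, and "the series" means these few. Any claim that something is new, unique, unknown or untested is made for them only; others in the source may bear on it.

Compound 1 `C=C1C(=O)[C@]23C[C@@]1(O)CC[C@H]2c1ccc(OS(=O)(=O)c2ccc(C)cc2)c(C)c1[C@@H]3Cn1cc(-c2ccccn2)nn1`, compound 2 `C=C1C(=O)[C@]23C[C@@]1(O)CC[C@H]2c1ccc(OS(=O)(=O)c2ccc(C)cc2)c(C)c1[C@@H]3Cn1cc(-c2ccc(Cl)cc2)nn1` and compound 3 `Cc1ccc(S(=O)(=O)Oc2ccc3c(c2C)[C@H](Cn2cc(-c4ccc(Cl)cc4)nn2)[C@@]24CC(=O)[C@@](C)(CC[C@@H]32)C4)cc1` have been measured. In a functional assay on SW480 cells (Homo sapiens) for cytotoxicity, read by MTT assay, with a stated time of 4 days (a higher number here means a weaker inhibitor, a lower number a stronger inhibitor), compound 1 gives 1970 nM. In this assay compound 2 gives 2390 nM. Compound 3 reaches only a limit in this assay, > 20000 nM, and that limit is the limit of > 20000 nM in this assay, at which 1 of the 3 values shown sits.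

The change from compound 2 to compound 1 is pyridin-2-yl in place of 4-chlorophenyl on an aromatic carbon, and it gives a 1.2-fold lower number from compound 2 to compound 1 (0.08 log units; within the scatter). Compound 4 `Cc1ccc(S(=O)(=O)Oc2ccc3c(c2C)[C@H](Cn2cc(-c4ccccn4)nn2)[C@@]24CC(=O)[C@@](C)(CC[C@@H]32)C4)cc1` is not yet measured; it differs from compound 3 by pyridin-2-yl in place of 4-chlorophenyl on an aromatic carbon, the same kind of change on the other core. How the core of compound 3 differs from the core of compound 2 is not broken down here.

Because a 1.2-fold lower number from compound 2 to compound 1 (0.08 log units; within the scatter) stays within the scatter, compound 4 is expected to stay close to compound 3 in this assay. Compound 4 is estimated at 25000 nM, between 8000 nM and 80000 nM, an expected step that the limit leaves unreadable from compound 3 to compound 4, and it may itself end only at a limit.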

Compound 4, half-maximal inhibitory concentration: > 20000 nM
Compound 4: only a limit was reported; the forecaster's own chance of this, stated with the estimate: 75%; the middle value does not contradict the limit.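

In this assay no step can be read between compound 3 and compound 4, as both end only at a limit: the limit of > 20000 nM in this assay, at which 2 of the 4 values shown sit. From the compounds shown here alone, what remains open is whether pyridin-2-yl in place of 4-chlorophenyl changes anything on this core, as the values of compound 3 and compound 4 cannot show it.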